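Methylation of a ring hydroxyl on two related cores

The source may hold more compounds than are shown below. What is called first, only, known or untested is meant among the compounds shown, and "the series" means these compounds.

Compound 1 `O=C(O)Cn1c(=O)c(/C=C/c2ccc(O)c(O)c2)nc2cc(Br)cnc21` reaches 95.8% in a functional assay, read by spectrophotometry, with a stated time of 30 min, tested at 100 uM; on this read-out higher numbers stand for a stronger effect at the one concentration tested and lower numbers for a weaker effect. Compound 3 `COc1cc(/C=C/c2nc3cc(Br)cnc3n(CC(=O)O)c2=O)ccc1O` carries methyl in place of hydrogen on an oxygen on an aromatic ring and gives 90.1% in this assay, so the step of a number 5.7 percentage points lower from compound 1 to compound 3 (within the scatter) is small. Compound 2 `COc1c(O)cc(-c2nc3cccnc3n(CC(=O)O)c2=O)cc1O`, built on a different core, gives 45.6% in this assay, the lowest of the three values; how its core differs from that of compound 1 is not broken down here. Compound 4 `COc1cc(-c2nc3cccnc3n(CC(=O)O)c2=O)cc(O)c1OC` carries the same change, (methyl in place of hydrogen on an oxygen on an aromatic ring), made on the core of compound 2, the second of two occurrences of this change among the compounds shown. Because the earlier step of a number 5.7 percentage points lower from compound 1 to compound 3 (within the scatter) stayed within the scatter, a step of similar small size, a number 3.6 percentage points lower from compound 2 to compound 4 (within the scatter), is expected here. Compound 4 is therefore estimated at 42% in this assay, between 26% and 58%, resting on compound 2 at 45.6% alone.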

Compound 4, a percentage reported as activity, at one concentration (the size of the read-out at that concentration, not a potency): 20.5%
Compound 4: middle estimate off by 21.5 percentage points, on the high side; measured number outside the range, below it.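

In this assay the hydroxy to methoxy change gives a number 25.1 percentage points lower from compound 2 to compound 4 (beyond the scatter), and the step does not keep its size from one core to the other: the same change on two cores in this assay, a number 5.7 percentage points lower (within the scatter) from compound 1 to compound 3 and a number 25.1 percentage points lower (beyond the scatter) from compound 2 to compound 4, 19.4 percentage points apart, beyond the scatter of two such steps

A step read on one core is therefore a poor guide to the same change on the other core in this series. Two pairs do not show which feature of the cores sets the size of the step, and they give no rule for any further core.

The compounds shown leave open whether ethoxy or an amine in place of the same hydroxy would follow the step on the core of compound 1 or the step on the core of compound 2. They also speak only of a stronger or weaker effect at the one concentration tested and leave open how the effect would compare at any other concentration.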